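The compounds below may be only part of what the source reports. "The series", "measured", "known", "first", "only" and "open" are said of these compounds alone.

Working notes on the series. Compound 1, `Cc1nnc(CN(C)C)n1-c1ccc(Cl)cc1C(=O)c1ccccc1`, gives 1.1 mg/kg in a functional assay on the whole organism (strain CF-1) for inhibition, with Mus musculus as the target; on this read-out higher numbers stand for an effect only at larger amounts of compound and lower numbers for an effect already at smaller amounts. Compound 2, `CNCc1nnc(C)n1-c1ccc(Cl)cc1C(=O)c1ccccc1`, gives 1.1 mg/kg in this assay, and the step of no change at the digits printed from compound 1 to compound 2 (within the scatter) shows that trimming the amine substituent leaves the read-out where it was. Compound 2 therefore stands level with compound 1. Compound 3, `CCNCc1nnc(C)n1-c1ccc(Cl)cc1C(=O)c1ccccc1`, differs from compound 2 by methyl in place of hydrogen on a saturated chain carbon bound to an amine nitrogen, a change at the same amine that has so far tolerated substitution. Among the compounds with values here, only one measured step bears on it, and that step was flat, so compound 3 is expected to show no change at the digits printed from compound 2 to compound 3 (within the scatter) in this assay, nothing beyond the scatter. The value for compound 3 is estimated at 1.1 mg/kg, within 0.5 mg/kg to 2.5 mg/kg.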

Compound 3, dose for half-maximal effect: 0.5 mg/kg
Compound 3: the middle estimate sits 2.2-fold (0.34 log units) above what was measured; low and high end bracket the measured number.
By their numbers in this assay, from the lowest: compound 3; then compounds 1 and 2 (each within the scatter of the next).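

In this assay, within the data shown here, methyl in place of hydrogen on a saturated chain carbon bound to an amine nitrogen gives a 2.2-fold lower number from compound 2 to compound 3 (0.34 log units; beyond the scatter) and is the first step beyond the scatter, so this amine substituent does not tolerate every change without effect. Ethylamino in place of dimethylamino on a saturated chain carbon bound to an aromatic carbon gives a 2.2-fold lower number from compound 1 to compound 3 (0.34 log units; beyond the scatter) and sets ethylamino apart from both earlier amine groups. No evidence on the origin of these steps is available.

On these data alone, whether a longer chain such as propyl on the amine nitrogen, or the unsubstituted primary amine, would shift the read-out remains open.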